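The source may report more compounds than this note shows. Statements on the series, on what has been measured and on what is new or still open speak of the compounds shown alone.

Compound 1 `CC(C)N1CCN(Cc2csc(N)c2C(=O)c2ccc(Cl)cc2)CC1`: -7.4%
Compound 2 `Nc1scc(CN2CCN(c3cccc(F)c3)CC2)c1C(=O)c1ccc(Cl)cc1`: -82%

Both compounds were tested in a functional assay on CHO cells with adenosine receptor A1 (Homo sapiens) as the target, read by cAMP accumulation and immunoassay, with a stated time of 6 min, tested at 10 uM; on this read-out higher numbers stand for a weaker effect at the one concentration tested and lower numbers for a stronger effect. Going by the values given here, compound 2 stands lowest of the two numbers, which on this read-out means the stronger effect; the only step measured so far, a number 74.6 percentage points lower from compound 1 to compound 2 (beyond the scatter), is the one that separates it from its nearest neighbour.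

Compound 3 `Nc1scc(CN2CCN(c3c(F)cc(F)cc3F)CC2)c1C(=O)c1ccc(Cl)cc1` has not yet been measured. It differs from compound 2 in one place: 2,4,6-trifluorophenyl in place of 3-fluorophenyl on an amine nitrogen in a ring. The measured step swapped a small branched chain for a fluorinated aromatic ring, whereas this change keeps an aromatic ring on the same nitrogen and only alters how it is fluorinated, so that step bears on it only loosely. A step within or just beyond the scatter is therefore expected, most likely toward a slightly weaker effect. Compound 3 is estimated at -70%, with a range of -95% to -30%, which would mean an expected a number 12 percentage points higher from compound 2 to compound 3 (beyond the scatter).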

Compound 3, a percentage reported as activity, at one concentration (the size of the read-out at that concentration, not a potency): -78%
Beside the measured number, compound 3's estimate is 8 percentage points above it; low and high end bracket the measured number.
By their numbers in this assay, from the lowest: compounds 2 and 3 (each within the scatter of the next); then compound 1.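

In this assay, the 2,4,6-trifluorophenyl group on the amine nitrogen reads much like the 3-fluorophenyl group, with a number 4 percentage points higher from compound 2 to compound 3 (within the scatter), so among these two compounds the number of fluorines on the ring makes no measurable difference. The large step away from the isopropyl compound also appears with this second fluorinated phenyl group, as a number 70.6 percentage points lower from compound 1 to compound 3 (beyond the scatter), so it no longer rests on a single aromatic group. Nothing available explains these numbers.

Going by these compounds, what a plain phenyl ring, a chlorophenyl ring or a benzyl group would give on this nitrogen stays open, and so does whether fluorine is needed at all. On these data alone, each number also comes from a single concentration, so any difference in potency between compound 2 and compound 3 remains unknown.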